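The source may hold more compounds than are shown below. What is called first, only, known or untested is meant among the compounds shown, and "the series" means these compounds.

Compound 2 `COc1ccc(C2=C(c3ccc(SC)cc3)CC3CCCN3C2=O)cc1C` is measured in a functional assay on DU-145 cells (Homo sapiens) for cytotoxicity (a higher number here means a weaker inhibitor of growth, a lower number a stronger inhibitor of growth), at 900 nM, level with compound 1 `COc1ccc(C2=C(c3ccc(SC)cc3)CC3CCCN3C2=O)cc1Br`, which in this assay gives 900 nM. Within the data shown here, the one measured step, no change at the digits printed from compound 1 to compound 2 (within the scatter), was flat within the scatter. Compound 3 `CSc1ccc(C2=C(c3ccc(SC)cc3)C(=O)N3CCCC3C2)cc1` follows from compound 2 by 4-(methylsulfanyl)phenyl in place of 4-methoxy-3-methylphenyl on a double-bonded ring carbon. Among the measured compounds shown here, no measured step touches the methoxy or the methylsulfanyl group, so the flat step from compound 1 to compound 2 bears only loosely on this change. For compound 3 the expected step is no change at the digits printed from compound 2 to compound 3 (within the scatter), none beyond the scatter. Compound 3 is therefore estimated at 900 nM, within 300 nM to 3000 nM.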

Compound 3, concentration for 50% growth inhibition: 8000 nM
Compound 3: middle estimate off by 8.9-fold (0.95 log units), on the low side, and the stated range ends below it.
By their numbers in this assay, from the lowest: compounds 1 and 2 (each within the scatter of the next); then compound 3.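

In this assay, this position proves sensitive to the aryl group it carries: 4-(methylsulfanyl)phenyl in place of 4-methoxy-3-methylphenyl gives an 8.9-fold higher number from compound 2 to compound 3 (0.95 log units; beyond the scatter), and in place of 3-bromo-4-methoxyphenyl it gives an 8.9-fold higher number from compound 1 to compound 3 (0.95 log units; beyond the scatter). The earlier swap of bromo for methyl left the number flat, whereas exchanging the whole aryl group does not. Nothing available explains this shift.

Whether the loss follows the departure of the methoxy group or the arrival of methylsulfanyl cannot be separated here. Going by these compounds, how a 4-hydroxyphenyl or 4-aminophenyl group would read at this place also remains open.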